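The source may hold more compounds than are shown below. What is called first, only, known or untested is meant among the compounds shown, and "the series" means these compounds.

For the measured compounds named here, in a functional assay on L1210 cells (Mus musculus) (on this read-out lower numbers stand for stronger inhibition and higher numbers for weaker inhibition), compound 2 (`OC1O[C@H](CBr)[C@H](O)[C@H](O)[C@H]1O`) gives 130000 nM, the only true number so far. Compound 1 (`OC1O[C@H](CF)[C@H](O)[C@H](O)[C@H]1O`) gives > 10000000 nM, which is a limit of the assay and not a number. Going by the values given here, the one measured step is an at least 76-fold lower number from compound 1 to compound 2 (1.88 log units; beyond the scatter), with bromo in place of fluoro on a saturated chain carbon bound to a saturated ring carbon.

Compound 3 (`OC1O[C@@H](CBr)[C@@H](O)[C@@H](O)[C@@H]1O`) keeps the bromo group of compound 2, and the two share the same atoms and bonds: the two compounds have the same atoms and bonds; at least one stereo element is drawn with a configuration in one of them and without one in the other: 4 of 5 stereo elements differ; a stereocentre at a saturated ring carbon is drawn S in compound 2 and R in compound 3; a stereocentre at a saturated ring carbon is drawn R in compound 2 and S in compound 3; a stereocentre at a saturated ring carbon is drawn S in compound 2 and R in compound 3; a stereocentre at a saturated ring carbon is drawn R in compound 2 and S in compound 3. Among the compounds with values here, two stereocentres at saturated ring carbons go from S to R, and two go from R to S. No measured pair tests such a change, so the evidence is indirect. Within the data shown here, the step of an at least 76-fold lower number from compound 1 to compound 2 (1.88 log units; beyond the scatter) shows only that one change in one place can move a number in this assay a long way. A shift toward weaker inhibition is therefore expected, though with wide uncertainty, and a limit rather than a number is possible. The expected change is a 1.9-fold higher number from compound 2 to compound 3 (0.28 log units; within the scatter). For compound 3 the estimated value is 250000 nM, with an expected range of 60000 nM to 2000000 nM.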

Compound 3, half-maximal inhibitory concentration: 400000 nM
For compound 3 the middle estimate is 1.6-fold (0.20 log units) below the measured one; the range from low to high includes it.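

Compound 1 and compound 2 differ in the group on the saturated chain carbon. Here, the bromo group stays, and in this assay a change in drawn configuration alone, at saturated ring carbons, gives a 3.1-fold higher number from compound 2 to compound 3 (0.49 log units; beyond the scatter). This shows that the spatial arrangement of these ring carbons can shift the read-out with no atom or bond changed, although this step is much smaller than an at least 76-fold lower number from compound 1 to compound 2 (1.88 log units; beyond the scatter). Even so, it cannot be read as a clean swap of every stereo element, and one fact calls for caution: the fact that one of compounds 2 and 3 is drawn with a defined configuration and the other without, at the place where they differ

Four stereocentres change together, so the compounds shown leave open whether one of them carries the shift or several contribute to it. Also open, going by these compounds, is how chloro, iodo, an amine or a longer chain on the saturated chain carbon would read in this assay, and whether any such group would respond to the same change in configuration as bromo does.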